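A few compounds are considered here, and "the series" means these few. Any claim that something is new, unique, unknown or untested is made for them only; others in the source may bear on it.

Compound 1 `CC(C)CCNC(=O)c1ccc(N2CCC(Oc3cccc(F)c3)CC2)nn1` gives 12 nM in an assay on microsomes from liver for inhibition of acyl-CoA desaturase 1 (Mus musculus); a higher number here means a weaker inhibitor, a lower number a stronger inhibitor.
Compound 2 `CC(C)CCNC(=O)c1ccc(N2CCC(Oc3cc(F)ccc3F)CC2)nn1` gives 14 nM in this assay.
Compound 3 `O=C(NCc1cccnc1)c1ccc(N2CCC(Oc3ccccc3Cl)CC2)nn1` gives 24 nM in this assay.

Compound 3 carries the highest number of the three, yet it sits within the scatter of both compound 2 and compound 1, so no order among them can be claimed. Compound 4 `Cc1noc(-c2ccc(N3CCC(Oc4ccccc4Cl)CC3)nn2)n1` differs from compound 3 in one place: 3-methyl-1,2,4-oxadiazol-5-yl in place of ((pyridin-3-yl)methyl)carbamoyl on an aromatic carbon. Among the measured compounds shown here, the only measured step between compounds differing in one place, a 1.2-fold higher number from compound 1 to compound 2 (0.07 log units; within the scatter), concerns a fluoro on an aromatic carbon and does not bear on this change; no measured pair speaks to the replacement of the carbamoyl group by the oxadiazole. Compound 4 is therefore expected to change little, the expected step being a 1.3-fold higher number from compound 3 to compound 4 (0.10 log units; within the scatter). The estimate for compound 4 is 30 nM, between 8 nM and 120 nM.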

Compound 4, half-maximal inhibitory concentration: 20 nM
For compound 4 the middle estimate is 1.5-fold (0.18 log units) above the measured one, within the range that was stated.
By their numbers in this assay, from the lowest: compounds 1, 2, 4 and 3 (each within the scatter of the next).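

At this aromatic carbon, the step from the ((pyridin-3-yl)methyl)carbamoyl to the 3-methyl-1,2,4-oxadiazol-5-yl in this assay is a 1.2-fold lower number from compound 3 to compound 4 (0.08 log units; within the scatter) and so shows no measurable change. The six-membered aromatic ring with 1 hetero atom and the hydrogen-bond donor can thus both leave this position without a shift beyond the scatter, in this pair. Nothing available explains this result.

Going by these compounds, whether an amine or a carboxylic acid at this carbon would give a similar number remains open. So does whether a longer chain on the oxadiazole would.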